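The compounds below may be only part of what the source reports. "The series", "measured", "known", "first", "only" and "open" are said of these compounds alone.

Measured so far:
compound 1 `CCCc1c(OCCCOc2cc(O)c(C(C)=O)cc2CC)cccc1OCc1ccccc1C(=O)O`, 244 nM
compound 2 `CCCc1cc(Oc2ccc(C(=O)O)cc2)ccc1OCCCOc1cc(O)c(C(C)=O)cc1CC`, 1200 nM
compound 3 `CCc1cc(C(C)=O)c(O)cc1OCCCOc1ccc(Oc2ccc(C(=O)O)cc2)cc1`, 90 nM

Of the compounds shown here, three have been measured in an assay on membranes from lung (Cavia porcellus) for inhibition of leukotriene B4 receptor (Homo sapiens); on this read-out higher numbers stand for weaker inhibition and lower numbers for stronger inhibition. Compound 2 stands at the weak end of the set: its number is the highest of the three, with compound 1 nearest at 244 nM and compound 3 furthest at 90 nM. For the measured compounds named here, the one single-change step among them, a 13-fold lower number from compound 2 to compound 3 (1.12 log units; beyond the scatter), concerns the propyl group on the shared core and not the carboxyphenyl part.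

Compound 4 `CCCc1cc(Oc2cccc(C(=O)O)c2)ccc1OCCCOc1cc(O)c(C(C)=O)cc1CC` differs from compound 2 by 3-carboxyphenyl in place of 4-carboxyphenyl on an oxygen on an aromatic ring. Going by the values given here, no measured pair shows a move of the carboxylic acid from one position of this ring to another, so the step from compound 2 to compound 3 gives no direct guide, and compound 1 carries its acid on a different kind of group altogether. The direction of the change is therefore open. The estimate for compound 4 is 1000 nM, within 300 nM to 3500 nM, which as a step is expected to be a 1.2-fold lower number from compound 2 to compound 4 (0.08 log units; within the scatter), a change not confidently beyond the scatter.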

Compound 4, inhibition constant: 256 nM
Estimate against measurement, compound 4: 3.9-fold (0.59 log units) above; measured number outside the range, below it.
By their numbers in this assay, from the lowest: compound 3; then compounds 1 and 4 (each within the scatter of the next); then compound 2.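

Within this assay, replacing 4-carboxyphenyl with 3-carboxyphenyl on an oxygen on an aromatic ring gives a 4.7-fold lower number from compound 2 to compound 4 (0.67 log units; beyond the scatter), a modest step, so this position responds to where the carboxylic acid sits on the ring even though compound 2 and compound 4 have the same atoms, joined differently. For the compounds shown here, the only single-change step known before was at the propyl group, a 13-fold lower number from compound 2 to compound 3 (1.12 log units; beyond the scatter), and the new step shows that the carboxyphenyl part can also shift the number beyond the scatter, here with the propyl group kept in place. No available evidence bears on what underlies this shift.

The compounds shown leave open whether the same change would act alike on the core of compound 3, which carries hydrogen in place of propyl, so it is unknown whether the two steps would add up, cancel or do neither. They also leave open what a tetrazole or a carboxymethyl group would do in place of the carboxylic acid on this ring.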